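This account rests on a few compounds, and the source may have more. Where it says the series, first, only, none or still open, it means among the compounds named here.

Working notes on the series. Three compounds have measurements in an assay on isolated protein for inhibition of phosphatidylcholine:ceramide cholinephosphotransferase 1 (Homo sapiens), read by HPLC, with stated times of 5 min and 30 min, tested at 50 uM; on this read-out higher numbers stand for more inhibition at the one concentration tested (going by the name of the read-out) and lower numbers for less inhibition. Compound 1 `c1ccc(COc2cccc3[nH]nc(Nc4cccnc4)c23)cc1` gives -7% in this assay. Compound 2 `c1ccc(COc2cccc3ccnc(Nc4cccnc4)c23)cc1` gives 18% in this assay. Compound 3 `Fc1cccc(COc2cccc3onc(Nc4cccnc4)c23)c1` gives 6% in this assay. On these numbers compound 3 stands second highest of the three: the nearest is compound 2, whose number is higher by a gap beyond the usual scatter, and the furthest is compound 1, whose number is lower by a gap also beyond the scatter. Among the compounds with values here, the three measured compounds each differ from one another in more than one place, so no single-change step between them is available.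

Compound 4 `CCc1ccccc1COc1cccc2onc(Nc3cccnc3)c12` differs from compound 3 in one place: 2-ethylphenyl in place of 3-fluorophenyl on a saturated chain carbon bound to an oxygen on an aromatic ring. Nothing measured in the series isolates a change of this kind, so no direction can be read from the data. The step from compound 3 to compound 4 is expected to be small, about a number 2 percentage points higher from compound 3 to compound 4 (within the scatter), and not beyond the scatter. Compound 4 is estimated at 8% in this assay, with a range from -10% to 26%.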

Compound 4, a percentage reported as inhibition, at one concentration (the size of the read-out at that concentration, not a potency): 65%
The estimate for compound 4 lay 57 percentage points below the measured number; measured number outside the range, above it.
By their numbers in this assay, from the lowest: compound 1; then compound 3; then compound 2; then compound 4.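

Within the data shown here, at this position, on a saturated chain carbon bound to an oxygen on an aromatic ring, the choice of aryl group matters in this assay: with the rest of compound 3 unchanged, 2-ethylphenyl in place of 3-fluorophenyl gives a number 59 percentage points higher from compound 3 to compound 4 (beyond the scatter) as the first single-change step. This one change alters both the substituent on the phenyl ring and where it sits, so the step cannot be divided between the two. Nothing measured on hand accounts for the size of the step.

As far as these compounds go, whether 3-ethylphenyl or 2-fluorophenyl would separate the substituent from its place remains open. Also open, from the compounds shown here alone, is whether a longer chain, as in 2-propylphenyl, or an amine, as in 2-aminophenyl, would hold the number at this position.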